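Amide in Place of Amine on the Ring Nitrogen

The source may hold more compounds than are shown below. What is called first, only, known or untested is meant among the compounds shown, and "the series" means these compounds.

Of the compounds shown here, two built on a shared core have been measured in an assay on isolated protein for activation of cGMP-dependent protein kinase 1 (Homo sapiens), read by ADP-Glo, with stated times of 30 min and 2 h, in the presence of a further agent that is not named here; a lower number here means that less compound is needed, a higher number that more compound is needed for the effect. Compound 1 `OC[C@@H](O[C@H]1CCCN(Cc2nc3ccccc3[nH]2)[C@H]1c1ccccc1)c1cc(Cl)cc(Cl)c1` gives 4700 nM, and compound 2 `Nc1cc(C(=O)O)ccc1CN1CCC[C@H](O[C@H](CO)c2cc(Cl)cc(Cl)c2)[C@@H]1c1ccccc1` gives 290 nM. Compound 2 therefore holds the lower of the two numbers, separated from compound 1 by the step of a 16-fold lower number from compound 1 to compound 2 (1.21 log units; beyond the scatter). Compound 3 `Cc1cc(C(=O)O)ccc1C(=O)N1CCC[C@H](O[C@H](CO)c2cc(Cl)cc(Cl)c2)[C@@H]1c1ccccc1` has not yet been measured; it differs from compound 2 in one place: a group of 12 heavy atoms (9 carbon, 3 oxygen; one six-membered aromatic ring of carbon only) in place of a group of 11 heavy atoms (8 carbon, 1 nitrogen, 2 oxygen; one six-membered aromatic ring of carbon only), on an amine nitrogen in a ring. Going by the values given here, no measured step matches this change. Among the compounds with values here, the only step seen, a 16-fold lower number from compound 1 to compound 2 (1.21 log units; beyond the scatter), exchanged one group on the same ring nitrogen for another and was large, so a change at this position is unlikely to be silent. Lacking a closer precedent, compound 3 is expected to come out weaker than compound 2, with the step of a 5.2-fold higher number from compound 2 to compound 3 (0.71 log units; beyond the scatter) as the estimate. The estimated value for compound 3 is 1500 nM, with a likely range from 300 nM to 8000 nM.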

Compound 3, half-maximal effective concentration: > 200000 nM
Compound 3 ended at the assay's limit (the forecaster's own chance of this, stated with the estimate: 10%); middle value at least 130-fold (2.12 log units) from the limit.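

Compound 3 stands at a limit of this assay, not at a measured number: the limit of > 200000 nM in this assay, at which 1 of the 3 values shown sits. Even so, the change on the amine nitrogen in the ring can be read as an at least 680-fold higher number from compound 2 to compound 3 (2.83 log units; beyond the scatter), and the new group also falls behind the 1H-benzimidazol-2-yl group, with an at least 42-fold higher number from compound 1 to compound 3 (1.62 log units; beyond the scatter); the earlier step showed that this position responds, and these show how much can be lost there. Compound 3 keeps the carboxylic acid of compound 2, yet needs more compound than compound 1, which has none, so a carboxylic acid on this ring does not by itself secure the effect.

The entering group differs in two ways at once: a carbonyl replaces the saturated carbon on the ring nitrogen, and a methyl replaces the amine. Telling these apart would take a carbonyl-linked group that keeps the amine, or a benzyl group that carries the methyl.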